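A Trifluoro Group Replaces a Ring on the Chain

A few compounds are considered here, and "the series" means these few. Any claim that something is new, unique, unknown or untested is made for them only; others in the source may bear on it.

Compound 1 `O=C(CCCCCCCNC(=O)c1cc(=O)c(O)co1)Nc1ccccc1` is the starting point. In a functional assay on HCT-116 cells (Homo sapiens) for inhibition, read by colorimetric assay, with a stated time of 3 days (on this read-out higher numbers stand for weaker inhibition and lower numbers for stronger inhibition), compound 1 reads > 100000 nM, which is a limit of the assay and not a number. Compound 2 `C/C(=N\O)C(=O)NCCCCCCC(=O)Nc1ccccc1` reads > 100000 nM, also a limit. Compound 3 `O=C(CCCCNC(=O)c1cc(=O)c(O)co1)Nc1ccccc1` reads > 100000 nM, again a limit.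

Compound 4 `O=C(CCCCCCCNC(=O)C(O)(O)C(F)(F)F)Nc1ccccc1` differs from compound 1 at one place, a carbonyl carbon, where 2,2,2-trifluoro-1,1-dihydroxyethyl enters: a group of 7 heavy atoms (2 carbon, 2 oxygen, 3 fluorine; no ring) in place of a group of 8 heavy atoms (5 carbon, 3 oxygen; one six-membered aromatic ring with 1 hetero atom), on a carbonyl carbon. Only a small shift toward stronger inhibition in this assay is expected for compound 4 because of the limit of > 100000 nM in this assay, at which 3 of the 3 values shown sit, a group that includes compound 1. The estimated change is an at least 1.6-fold lower number from compound 1 to compound 4 (0.22 log units; that floor lies within the scatter). For compound 4 the expected value is 60000 nM, with an estimated range of 15000 nM to 150000 nM.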

Compound 4, half-maximal inhibitory concentration: 41700 nM
Estimate against measurement, compound 4: 1.4-fold (0.16 log units) above; the measured number falls inside the stated range.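

Going by these compounds alone, on a carbonyl carbon, 2,2,2-trifluoro-1,1-dihydroxyethyl gives the only reading in this assay that is a number and not a limit. Putting it in place of the ring-bearing group gives an at least 2.3-fold lower number from compound 1 to compound 4 (0.37 log units; beyond the scatter). The full size of this step stays unknown because compound 1 gives only a limit: the limit of > 100000 nM in this assay, at which 3 of the 4 values shown sit.

The compounds shown leave open which part of the new group matters, the trifluoromethyl or the two hydroxyl groups. They also leave open how a carboxylic acid would read at this place, or how the new group would read on a shorter chain.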